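The compounds below may be only part of what the source reports. "The series", "measured", "known", "first", "only" and "open" are said of these compounds alone.

In a functional assay on a cell-free system (Platelet, plasma, Homo sapiens) for inhibition, read by turbidimetry, with a stated time of 3 min (on this read-out higher numbers stand for weaker inhibition and lower numbers for stronger inhibition), compound 1 `COc1ccc(-n2nc(C(=O)N3CCCCC3)cc2-c2ccc(Cl)cc2)nn1` gives 41 nM and compound 2 `COc1ccc(-n2nc(C(=O)N3CCOCC3)cc2-c2ccc(Cl)cc2)nn1` gives 83 nM, so compound 2 has the higher number of the two and is the weaker inhibitor. Compound 3 `COc1ccc(-n2nc(C(=O)Nc3ccncc3)cc2-c2ccc(Cl)cc2)nn1` differs from it in one group: (pyridin-4-yl)amino in place of morpholin-4-yl on a carbonyl carbon. In short, (pyridin-4-yl)amino stands in place of morpholin-4-yl on a carbonyl carbon. Among the measured compounds shown here, only one measured step bears on this, a modest one at the same carbonyl carbon: a 2.0-fold higher number from compound 1 to compound 2 (0.31 log units; beyond the scatter). It offers no aromatic group for comparison, so no step beyond the scatter is expected, in either direction. The estimated step is a 1.4-fold lower number from compound 2 to compound 3 (0.14 log units; within the scatter). For compound 3 the expected value is 60 nM, within a range of 15 nM to 250 nM.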

Compound 3, half-maximal inhibitory concentration: 110 nM
Beside the measured number, compound 3's estimate is 1.8-fold (0.26 log units) below it, and the stated range covers the measured number.
By their numbers in this assay, from the lowest: compound 1; then compounds 2 and 3 (each within the scatter of the next).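

In this assay an aromatic ring can stand at this carbonyl carbon with a 1.3-fold higher number from compound 2 to compound 3 (0.12 log units; within the scatter), so (pyridin-4-yl)amino and morpholin-4-yl cannot be told apart here, even though the entering group carries a hydrogen-bond donor and morpholin-4-yl carries none. Against piperidin-1-yl, the same change gives a 2.7-fold higher number from compound 1 to compound 3 (0.43 log units; beyond the scatter), which leaves compound 1 with the lowest number of the three. No measurement shown gives a reason for these steps. Still open, from the compounds shown here alone, is whether the ring nitrogen of the pyridine matters, which a phenylamino group at this carbonyl carbon would test, and how a small open-chain amine such as dimethylamino would compare.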